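The source may report more compounds than this note shows. Statements on the series, on what has been measured and on what is new or still open speak of the compounds shown alone.

Of the compounds shown here, three built on one shared core have so far been tested in a functional assay on HeLa cells (Homo sapiens) for antiproliferative activity, read by sulforhodamine B assay, with a stated time of 72 h; a higher number here means a weaker inhibitor, a lower number a stronger inhibitor. Compound 1 `Cc1cc(NS(=O)(=O)c2ccc(Nc3nncc4ccccc34)cc2)no1` gives 13 nM. Compound 2 `O=S(=O)(Nc1ccccn1)c1ccc(Nc2nncc3ccccc23)cc1` gives 26 nM. Compound 3 `NS(=O)(=O)c1ccc(Nc2nncc3ccccc23)cc1` gives 12 nM, the lowest of the three numbers; its gap to compound 1 lies within the scatter, while a 2.2-fold lower number from compound 2 to compound 3 (0.34 log units; beyond the scatter).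

The step now followed leads from compound 3 to compound 4 `O=S(=O)(Nc1nccs1)c1ccc(Nc2nncc3ccccc23)cc1`, which has not yet been measured in this assay. The change is 1,3-thiazol-2-yl in place of hydrogen on a sulfonamide nitrogen. Two measured steps speak to this change, because each of them also trades a group on the sulfonamide nitrogen for hydrogen: a 1.1-fold lower number from compound 1 to compound 3 (0.03 log units; within the scatter), and a 2.2-fold lower number from compound 2 to compound 3 (0.34 log units; beyond the scatter). Read in the reverse direction, placing a ring on that nitrogen has therefore cost nothing beyond the scatter in one case and a modest amount in the other. Since compound 4 carries a five-membered aromatic ring there, its number in this assay is expected to sit close to that of compound 3, with at most a small rise, so that a 1.3-fold higher number from compound 3 to compound 4 (0.12 log units; within the scatter) is expected. Compound 4 is estimated at 16 nM, within a range from 7 nM to 40 nM.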

Compound 4, half-maximal inhibitory concentration: 15 nM
Compound 4: the middle estimate sits 1.1-fold (0.03 log units) above what was measured; the measured number falls inside the stated range.
By their numbers in this assay, from the lowest: compounds 3, 1, 4 and 2 (each within the scatter of the next, the first and the last beyond it).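

In this assay, 1,3-thiazol-2-yl is a third ring to be placed on the sulfonamide nitrogen, and the number again stays close to that of the compound with only hydrogen there (a 1.3-fold higher number from compound 3 to compound 4 (0.10 log units; within the scatter)). This five-membered aromatic ring, the only one here with sulfur, also cannot be told apart from either of the other two rings, whether the five-membered 5-methyl-1,2-oxazol-3-yl (a 1.2-fold higher number from compound 1 to compound 4 (0.06 log units; within the scatter)) or the pyridin-2-yl (a 1.7-fold lower number from compound 2 to compound 4 (0.24 log units; within the scatter)). Across hydrogen and these three rings, the position therefore shows only one step beyond the scatter, the modest one already seen (a 2.2-fold lower number from compound 2 to compound 3 (0.34 log units; beyond the scatter)), and nothing shown explains why the number moves so little.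

The compounds leave open whether this tolerance extends beyond a hydrogen and unadorned or methyl-bearing rings, for instance to a plain methyl, an acetyl group or a longer alkyl chain on the same nitrogen. They also leave open what a carboxylic acid or an amine would do if carried on the thiazole ring, where a sharper change in the number might finally appear.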